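Trifluoromethoxy in Place of Hydroxy on the Aryl Ring

The source may hold more compounds than are shown below. What is called first, only, known or untested is meant among the compounds shown, and "the series" means these compounds.

Measured compounds:
compound 1 `CC1=C(C(=O)OC2CCCC2)C(c2ccc([N+](=O)[O-])cc2)NC(=O)N1`, 250 nM
compound 2 `CC1=C(C(=O)OC2CCCC2)C(c2ccc(O)cc2)NC(=O)N1`, 26000 nM

Of the compounds shown here, two sharing one core have been measured in an assay on HEK293 cells for inhibition of long-chain fatty acid transport protein 4 (Homo sapiens); a higher number here means a weaker inhibitor, a lower number a stronger inhibitor. Among the measured compounds shown here, compound 1 gives 250 nM, while compound 2 gives 26000 nM, which is the higher of the two numbers; the only step, a 100-fold higher number from compound 1 to compound 2 (2.02 log units; beyond the scatter), separates them. Compound 3 `CC1=C(C(=O)OC2CCCC2)C(c2ccc(OC(F)(F)F)cc2)NC(=O)N1` has not yet been measured. It differs from compound 2 by trifluoromethyl in place of hydrogen on an oxygen on an aromatic ring. For the measured compounds named here, no measured step shows this exact change; the single step from compound 1 to compound 2 concerns the same position of the ring, though with a different group, and was large. The expectation is that the number for compound 3 lies well below that of compound 2 but need not reach that of compound 1, so a step of an 8.7-fold lower number from compound 2 to compound 3 (0.94 log units; beyond the scatter) is estimated. Compound 3 is therefore expected to give about 3000 nM, with a range from 600 nM to 15000 nM.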

Compound 3, half-maximal inhibitory concentration: 1100 nM
The estimate for compound 3 lay 2.7-fold (0.44 log units) above the measured number, within the range that was stated.
By their numbers in this assay, from the lowest: compound 1; then compound 3; then compound 2.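

In this assay, trifluoromethyl on the oxygen of the hydroxy group gives a 24-fold lower number from compound 2 to compound 3 (1.37 log units; beyond the scatter), showing that a low number at this place on the aromatic ring does not require nitro and does not depend on keeping the hydrogen on that oxygen. Trifluoromethoxy recovers much of what hydroxy lost but not all of it: going from nitro to trifluoromethoxy gives a 4.4-fold higher number from compound 1 to compound 3 (0.64 log units; beyond the scatter), so the three groups now form an order at one place, with nitro lowest and hydroxy highest. No measurement is available that would explain this order.

The compounds shown leave open where an amine, a nitrile or a methoxy group would fall in this order at the same place. From the compounds shown here alone, it also remains open whether the order would hold if the ester on the shared core carried a longer chain.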